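A few compounds are considered here, and "the series" means these few. Any claim that something is new, unique, unknown or untested is made for them only; others in the source may bear on it.

Measured compounds:
- compound 1, `CCOC(=O)CCCCN(Cc1ccccc1)Cc1ccc2ccccc2c1`: 0%
- compound 2, `O=C(CN(Cc1ccccc1)Cc1ccc2ccccc2c1)OCCc1ccccc1`: 0%

Both measured compounds share a core built from a tertiary amine carrying a benzyl group and a naphthylmethyl group, and both end in an ester. In an assay on HEK293 cells for binding affinity to Substance-K receptor (Rattus norvegicus), read by FRET, tested at 10 uM (a lower number here means less inhibition, a higher number more inhibition at the concentration tested (going by the name of the read-out)), compound 1 gives 0%, and in this assay compound 2 gives 0%. The two readings lie level with each other within the scatter, so compound 2 stands at the floor of what this measurement can report, with no inhibition seen at the tested concentration.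

Compound 3, `CN1CCN(C(=O)CN(Cc2ccccc2)Cc2ccc3ccccc3c2)CC1`, has not yet been measured. It differs from compound 2 as follows: 4-methylpiperazin-1-yl in place of phenethyloxy on a carbonyl carbon. The ester is thus replaced by an amide carrying a second basic nitrogen.

Among the measured compounds shown here, no step between measured compounds is available, since compounds 1 and 2 differ in more than one place and both read the same. With both neighbours at zero, the step in this assay from compound 2 to compound 3 is expected to be small, at most a modest rise, and most likely none beyond the scatter: a number 5 percentage points higher from compound 2 to compound 3 (within the scatter). Compound 3 is therefore expected to give 5% in this assay, within a range from -10% to 25%.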

Compound 3, a percentage reported as inhibition, at one concentration (the size of the read-out at that concentration, not a potency): 0%
Compound 3: the middle estimate sits 5 percentage points above what was measured; low and high end bracket the measured number.
By their numbers in this assay, from the lowest: compounds 1, 2 and 3 (each within the scatter of the next).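

Replacing phenethyloxy with 4-methylpiperazin-1-yl on a carbonyl carbon turns the ester into an amide and brings in a non-aromatic ring with two nitrogens, yet this assay records no change at the digits printed from compound 2 to compound 3 (within the scatter) for this exchange. The wider change, (4-methylpiperazin-1-yl)carbonyl in place of 3-(ethoxycarbonyl)propyl on a saturated chain carbon bound to an amine nitrogen, likewise gives no change at the digits printed from compound 1 to compound 3 (within the scatter) in the same assay. The earlier pair showed only that two esters read alike, whereas these steps extend that flat result to an amide, though with all three compounds at the bottom of the scale, the assay cannot show whether any of these groups is better or worse than another.

No measurement shown here offers an explanation for the flat readings. From the compounds shown here alone, it remains open whether a carboxylic acid or a primary amine on that carbonyl carbon, or another group in place of the benzyl or naphthylmethyl group on the shared core, would produce any measurable inhibition at the concentration tested.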